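This account rests on a few compounds, and the source may have more. Where it says the series, first, only, none or still open, it means among the compounds named here.

Measured in a physicochemical assay for lipophilicity, in phosphate buffer, measured as octanol-water partition, at pH 6.8; a higher number here means a more lipophilic compound, a lower number a more polar compound: compound 1 `Cc1cn2c(N3CC[C@H](N(C)C)C3)c(-c3ccccc3)c(C)c(C#N)c2n1` gives 1.9. Compound 2 `CCN(CC)CCNc1c(-c2ccccc2)c(C)c(C#N)c2nc(C(C)(C)C)nn12` gives 3.3. Compound 3 `Cc1c(-c2ccccc2)c(N2CC[C@H](N(C)C)C2)n2nc(C3CC3)nc2c1C#N` gives 2.4.

Among these three numbers compound 3 stands second highest: its value lies above that of compound 1 and below that of compound 2, and both gaps are beyond the usual scatter. Compound 4 `Cc1nc2c(C#N)c(C)c(-c3ccccc3)c(N3CC[C@H](N(C)C)C3)n2n1` has not yet been measured. It differs from compound 3 in one place: methyl in place of cyclopropyl on an aromatic carbon. For the measured compounds named here, no measured pair with this same change is at hand, so the expectation rests on the change itself. Removing two carbon atoms and a ring in this way is expected to lower the number in this assay by a modest step, somewhat beyond the scatter. The step of a number 0.60 log units lower from compound 3 to compound 4 (beyond the scatter) is therefore expected to be a decrease. Compound 4 is estimated at 1.8, within a range from 1.3 to 2.3.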

Compound 4, distribution coefficient: 1.7
Compound 4: the middle estimate sits 0.10 log units above what was measured, and the stated range covers the measured number.
By their numbers in this assay, from the lowest: compounds 4 and 1 (each within the scatter of the next); then compound 3; then compound 2.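

For the compounds shown here, on the aromatic carbon between two ring nitrogen atoms, methyl in place of cyclopropyl gives, in this assay, a number 0.70 log units lower from compound 3 to compound 4 (beyond the scatter), the first change at this position that can be read on its own. Going by these compounds alone, compounds 3 and 4 differ in nothing else, so the step belongs to this swap alone, whereas the gaps among the earlier compounds involved more than one difference. No measurement shown here accounts for the size of the step.

This single step gives two points and no trend. Where a longer chain, an amine or a carboxylic acid at this carbon would fall remains open.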